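The compounds below may be only part of what the source reports. "The series", "measured", "known", "first", "only" and "open" are said of these compounds alone.

Measured compounds in a functional assay for inhibition, with Homo sapiens as the target; on this read-out higher numbers stand for weaker inhibition and lower numbers for stronger inhibition:

Compound 1 `CC(C)c1ncn2c(Nc3cc[nH]n3)nccc12` — a limit only, > 48000 nM.
Compound 2 `CCCc1ncn2c(SC)nncc12` — a limit only, > 48000 nM.
Compound 3 `CCCCCCCCCCCCCCCCCc1ncc2cnnc(S)n12` — a limit only, > 48000 nM.

Compound 1 stands nowhere in particular on the numbers: its result in this assay is a limit of the assay and not a number, and the same holds for the other two entries, since all three sit at the limit of > 48000 nM in this assay, at which 3 of the 3 values shown sit. Within the data shown here, no pair of measured compounds differs in a single place, so no measured step is available from which a trend could be read.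

The next compound, compound 4 `CCCc1ncn2c(Nc3cc[nH]n3)nccc12`, is related to compound 1 by a single change: propyl in place of isopropyl on an aromatic carbon. Among the measured compounds shown here, compounds 2 and 3 carry propyl and a long chain at a comparable position of their cores and also end at the limit, but their remaining substituents differ from those of compound 1, so they give no step.

With nothing measured beyond the limit, the step from compound 1 to compound 4 in this assay is expected to be none beyond the scatter: a step that the limit leaves unreadable from compound 1 to compound 4. Compound 4 is therefore estimated at 60000 nM, within 20000 nM to 200000 nM, and most likely again reported only as a limit.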

Compound 4, half-maximal inhibitory concentration: > 48000 nM
Compound 4: only a limit was reported; the forecaster's own chance of this, stated with the estimate: 85%; the middle value does not contradict the limit.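

In this assay compound 4 gives > 48000 nM as a limit of the assay and not a number. No step from compound 1 to compound 4 can be read, because both results are limits: the limit of > 48000 nM in this assay, at which 4 of the 4 values shown sit.

In this assay the compounds shown leave open whether propyl and isopropyl differ at all on the shared core, and which changes would give a measurable value.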